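The source may report more compounds than this note shows. Statements on the series, on what has been measured and on what is new or still open speak of the compounds shown alone.

Three compounds have been measured in an assay on isolated protein for inhibition of advanced glycosylation end product-specific receptor (Homo sapiens), read by FRET, with stated times of 30 min and 1 h, tested at 4 uM; a lower number here means less inhibition, a higher number more inhibition at the concentration tested (going by the name of the read-out):

Compound 1, `CC(C)N1CCC(Oc2ccc(-c3nc4ccc(Oc5ccc(Cl)cc5)cc4o3)cc2)CC1`, gives 12.7%.
Compound 2, `CN(C)CCCOc1ccc(-c2nc3ccc(Oc4ccc(Cl)cc4)cc3o2)cc1`, gives 4.9%.
Compound 3, `N[C@@H]1CCN(CCCOc2ccc(-c3nc4ccc(Oc5ccc(Cl)cc5)cc4o3)cc2)C1`, gives 19.6%.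

Compound 3 holds the highest of the three numbers in this assay. Its nearest neighbour is compound 1, and the step of a number 6.9 percentage points higher from compound 1 to compound 3 (within the scatter) lies within the scatter, so the two cannot be ordered. The step of a number 14.7 percentage points higher from compound 2 to compound 3 (beyond the scatter) is beyond the scatter and is the only real movement among the three; the step of a number 7.8 percentage points lower from compound 1 to compound 2 (within the scatter) stays within it.

Compound 4, `CN1CCN(CCCOc2ccc(-c3nc4ccc(Oc5ccc(Cl)cc5)cc4o3)cc2)CC1`, differs from compound 3 as follows: 4-methylpiperazin-1-yl in place of 3-aminopyrrolidin-1-yl on a saturated chain carbon, three bonds along the chain from an oxygen on an aromatic ring.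

For the measured compounds named here, the step that bears most directly on this change is the one from compound 2 to compound 3, where a 3-aminopyrrolidin-1-yl replacing a dimethylamino on the same chain carbon raised the number by a modest margin. Compound 4 carries no hydrogen-bond donor in the entering group, which it shares with compound 2 rather than compound 3. A step back toward the level of compound 2 is therefore expected, though the six-membered ring is not the same as the open dimethylamino and the size of the move is uncertain; the expected change is a number 9.6 percentage points lower from compound 3 to compound 4 (within the scatter). The estimate for compound 4 in this assay is 10%, within the range 0% to 22%.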

Compound 4, a percentage reported as inhibition, at one concentration (the size of the read-out at that concentration, not a potency): 24.3%
Estimate against measurement, compound 4: 14.3 percentage points below; measured number outside the range, above it.
By their numbers in this assay, from the lowest: compounds 2, 1, 3 and 4 (each within the scatter of the next, the first and the last beyond it).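

On the propyl chain, replacing the 3-aminopyrrolidin-1-yl with 4-methylpiperazin-1-yl leaves the result in this assay unresolved (a number 4.7 percentage points higher from compound 3 to compound 4 (within the scatter)), so the hydrogen-bond donor of the group leaving compound 3 is not required to hold the number at this level. Compound 4 also stands clear of the open-chain amine (a number 19.4 percentage points higher from compound 2 to compound 4 (beyond the scatter)): the lift over dimethylamino seen with compound 3 is thus not confined to a donor-bearing group, and both cyclic groups at this chain carbon exceed dimethylamino. Moving from the ether-linked 1-isopropylpiperidin-4-yl to the 3-(4-methylpiperazin-1-yl)propyl group also gives a step beyond the scatter (a number 11.6 percentage points higher from compound 1 to compound 4 (beyond the scatter)), whereas the corresponding step to compound 3 stayed within it. No supporting evidence is available to explain these differences.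

The compounds shown leave open whether the second ring nitrogen matters, which a piperidin-1-yl or morpholin-4-yl group on the same chain carbon would test. They also leave open how the number depends on the length of the chain, since a butyl or ethyl linker carrying 4-methylpiperazin-1-yl does not appear among them.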